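The source may hold more compounds than are shown below. What is called first, only, known or untested is meant among the compounds shown, and "the series" means these compounds.

Measured in a functional assay on T47D cells (Homo sapiens) for inhibition, read by CCK-8 assay, with a stated time of 72 h, tested at 1 uM; on this read-out lower numbers stand for less inhibition of growth and higher numbers for more inhibition of growth at the one concentration tested:
- compound 1 `CN(C)C(=O)c1cc2cnc(Nc3ccc(NC(=O)C4(C(=O)Nc5ccc(F)cc5)CC4)cc3)nc2n1C1CCCC1`: 74.7%
- compound 2 `CN(C)C(=O)c1cc2cnc(Nc3ccc(NC(=O)C4(C(=O)Nc5cccc(O)c5)CC4)cc3)nc2n1C1CCCC1`: 80.7%
- compound 3 `Nc1ccc(NC(=O)C2(C(=O)Nc3ccc(F)cc3)CC2)cc1F`: 5.6%

Compound 2 stands level with compound 1 within the scatter, and both lie far above compound 3, which does not carry the core of compound 1. Compound 2 therefore sits in the upper group of this small set, and no order can be drawn inside that group.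

Compound 4 `Cc1ccc(NC(=O)C2(C(=O)Nc3ccc(Nc4ncc5cc(C(=O)N(C)C)n(C6CCCC6)c5n4)cc3)CC2)cc1` has not yet been measured. It carries 4-methylphenyl in place of 3-hydroxyphenyl on an amide-type nitrogen, with the shared core unchanged.

Among the compounds with values here, only one measured step bears on this change. It is a number 6 percentage points higher from compound 1 to compound 2 (within the scatter), made at the same amide-type nitrogen, where 3-hydroxyphenyl replaced 4-fluorophenyl. Within the data shown here, that single step is thin evidence, and no measured compound yet carries 4-methylphenyl. Even so, the one exchange of aryl groups seen at this nitrogen left the read-out in this assay unmoved beyond the scatter, so no step beyond the scatter is expected here. The expected change is a number 4.7 percentage points lower from compound 2 to compound 4 (within the scatter), which is small and has no firm direction. For compound 4 the estimated value is 76%, with an expected range from 63% to 87%.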

Compound 4, percent growth inhibition at one concentration: 47.9%
The estimate for compound 4 lay 28.1 percentage points above the measured number; the measured number lies below the stated range.
By their numbers in this assay, from the lowest: compound 3; then compound 4; then compounds 1 and 2 (each within the scatter of the next).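

In this assay, the aryl group on this amide-type nitrogen now proves able to move the read-out beyond the scatter: 4-methylphenyl in place of 3-hydroxyphenyl gives the large step (a number 32.8 percentage points lower from compound 2 to compound 4 (beyond the scatter)), and methyl in place of fluoro on an aromatic carbon gives a modest one (a number 26.8 percentage points lower from compound 1 to compound 4 (beyond the scatter)). The level standing of compound 1 and compound 2 therefore does not extend to every aryl group at this nitrogen, and the loss of the hydroxyl alone cannot account for the fall, as compound 1 carries no hydroxyl yet stands level with compound 2. Nothing measured here explains why 4-methylphenyl stands apart from 4-fluorophenyl and 3-hydroxyphenyl.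

Open, from the compounds shown here alone, is whether the fall follows the methyl group itself or its place on the ring, which 3-methylphenyl would separate from 4-methylphenyl. Equally open, going by these compounds, is where unsubstituted phenyl, 4-chlorophenyl and 4-methoxyphenyl would fall relative to these aryl groups in this assay on the shared core.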